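Iodo for Ethynyl on a Methoxy Nucleoside Core

This account rests on a few compounds, and the source may have more. Where it says the series, first, only, none or still open, it means among the compounds named here.

Compound 1 `C#Cc1cn([C@@H]2O[C@H](CO)[C@@H](O)[C@H]2O)c2ncnc(NC)c12` bears an ethynyl group on its five-membered ring and a methylamino group on its six-membered ring. In a functional assay on CEM-DNR-bulk cells (Homo sapiens), read by MTT assay, with a stated time of 72 h (on this read-out higher numbers stand for weaker inhibition and lower numbers for stronger inhibition), compound 1 gives 18500 nM. Compound 2 `CNc1ncnc2c1c(I)cn2[C@@H]1O[C@H](CO)[C@@H](O)[C@H]1O` differs from it by iodo in place of ethynyl on an aromatic carbon. In this assay compound 2 is recorded only as a limit of the assay, > 20000 nM, not as a number. The change brought an at least 1.0-fold higher number from compound 1 to compound 2 (0.03 log units; that floor lies within the scatter), and the limit of > 20000 nM in this assay, at which 1 of the 3 values shown sits, leaves the true size of that step open.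

Compound 3 `C#Cc1cn([C@@H]2O[C@H](CO)[C@@H](O)[C@H]2O)c2ncnc(OC)c12` keeps the ethynyl group and differs from compound 1 by methoxy in place of methylamino on an aromatic carbon. In this assay compound 3 gives 3490 nM, the lower of the two numbers recorded, and the change brought a 5.3-fold lower number from compound 1 to compound 3 (0.72 log units; beyond the scatter).

Compound 4 `COc1ncnc2c1c(I)cn2[C@@H]1O[C@H](CO)[C@@H](O)[C@H]1O` has not yet been measured. It differs from compound 3 by iodo in place of ethynyl on an aromatic carbon, the same change that separates compound 1 from compound 2, the place being described in identical words in both cases. The two cores differ only in the group already named, methoxy in place of methylamino.

For the measured compounds named here, the step from compound 3 to compound 4 is expected to be a 2.6-fold higher number from compound 3 to compound 4 (0.41 log units; beyond the scatter), a rise resting on the single measured instance, an at least 1.0-fold higher number from compound 1 to compound 2 (0.03 log units; that floor lies within the scatter), whose size is open-ended. Compound 4 is therefore estimated at 9000 nM, with a likely range from 3500 nM to 25000 nM.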

Compound 4, half-maximal inhibitory concentration: > 20000 nM
Compound 4 gave a limit, no number; the forecaster's own chance of this, stated with the estimate: 30%; middle value at least 2.2-fold (0.34 log units) from the limit.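

In this assay compound 4 is recorded only as a limit of the assay, > 20000 nM, not as a number. On the core that carries methoxy, iodo in place of ethynyl brought an at least 5.7-fold higher number from compound 3 to compound 4 (0.75 log units; beyond the scatter). The step from compound 2 to compound 4 cannot be read, as both of its ends are limits.

Set beside the earlier step, the change can be sized on one core only, and the comparison stays unresolved: the same change on two cores in this assay, an at least 1.0-fold higher number (0.03 log units; that floor lies within the scatter) from compound 1 to compound 2 and an at least 5.7-fold higher number (0.75 log units; beyond the scatter) from compound 3 to compound 4; the limit leaves it open whether they differ. This shows that the swap costs clearly more than the scatter on the core with methoxy, and it fits a rise on both cores, but it does not show that the rise carries over with the same size or even that it occurs on the core with methylamino. Neither iodo compound gives a number that could settle this, and the ceiling of the read-out is reached often in so small a set: the limit of > 20000 nM in this assay, at which 2 of the 4 values shown sit.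

The compounds shown leave open how a chloro group or a longer chain would behave on the aromatic carbon that carries ethynyl or iodo. They also leave open whether an amine other than methylamino, or an ethoxy group, in the place of methoxy would change the size of the step.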